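The source may report more compounds than this note shows. Statements on the series, on what has been measured and on what is new or still open speak of the compounds shown alone.

In an assay on HEK293 cells for displacement of a labelled ligand from adenosine receptor A2b (Homo sapiens), read by radioligand binding, with a stated time of 30 min, tested at 1 uM (on this read-out higher numbers stand for more inhibition at the one concentration tested (going by the name of the read-out) and lower numbers for less inhibition), compound 2 `CC1=C(C(=O)OC(C(F)(F)F)C(F)(F)F)C(c2cccs2)NC(=O)N1` gives 1%, the only number shown for it there; a further entry carries no single number. Compound 1 `CC1=C(C(=O)OC(C)C(F)(F)F)C(c2cccs2)NC(=O)N1`, tested in the same way, gives 1%; 4% (2 entries), and its repeated entries the several entries of compound 1 in this assay, 1%; 4% (2 entries) lie within the usual scatter. Compound 3 `CC1=C(C(=O)OCC(F)(F)F)C(c2cccs2)NC(=O)N1` has not yet been measured. It differs from compound 2 by hydrogen in place of trifluoromethyl on a saturated chain carbon bound to an oxygen next to a carbonyl group and a saturated chain carbon. With both measured compounds near the bottom of the scale, the step in this assay is expected to be a number 2 percentage points higher from compound 2 to compound 3 (within the scatter), none beyond the scatter. Compound 3 is therefore expected to give about 3%, between 0% and 12%.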

Compound 3, a percentage reported as inhibition, at one concentration (the size of the read-out at that concentration, not a potency): 1%
Compound 3: middle estimate off by 2 percentage points, on the high side; low and high end bracket the measured number.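

In this assay, for the compounds shown here, exchanging trifluoromethyl for hydrogen on this saturated chain carbon gives the first step that can be read at this position: no change at the digits printed from compound 2 to compound 3 (within the scatter). Removing the trifluoromethyl group therefore leaves the reading near the bottom of the scale, so this change shows no gain in inhibition at the one concentration tested. The repeated entries show how such low readings vary: the several entries of compound 1 in this assay, 1%; 4% (2 entries)

As far as these compounds go, what an amine, a carboxylic acid or a longer chain on this carbon would do stays open. So does whether compound 2 and compound 3 would still read alike at another concentration.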